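A Dichlorophenyl Urea in Place of a Trifluoromethylphenyl Urea

This account rests on a few compounds, and the source may have more. Where it says the series, first, only, none or still open, it means among the compounds named here.

Compound 1 `O=C(Nc1cccc(-n2cc(-c3ccncc3)c(-c3ccc(Cl)c(O)c3)n2)c1)Nc1cccc(C(F)(F)F)c1` and compound 2 `COc1cc(-c2nn(-c3cccc(NC(=O)Nc4cc(C(F)(F)F)cc(C(F)(F)F)c4)c3)cc2-c2ccncc2)ccc1Cl` share a core that carries a urea on one phenyl ring. In a functional assay on SW-620 cells (Homo sapiens) for inhibition, read by sulforhodamine B assay, with a stated time of 48 h (a higher number here means a weaker inhibitor of growth, a lower number a stronger inhibitor of growth), compound 1 gives > 32500 nM, which is a limit of the assay and not a number. In this assay compound 2 gives 1860 nM. Compound 1 therefore sits at the limit of > 32500 nM in this assay, at which 1 of the 2 values shown sits. Compound 3 `O=C(Nc1cccc(-n2cc(-c3ccncc3)c(-c3ccc(Cl)c(O)c3)n2)c1)Nc1ccc(Cl)c(Cl)c1` differs from compound 1 by 3,4-dichlorophenyl in place of 3-(trifluoromethyl)phenyl on an amide-type nitrogen. Within the data shown here, no measured step of this kind exists here. The step of an at least 1.0-fold lower number from compound 1 to compound 3 (0.03 log units; that floor lies within the scatter) is the expected one, with no shift beyond the scatter anticipated. Compound 3 is expected to give 30000 nM, within a range from 8000 nM to 100000 nM.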

Compound 3, concentration for total growth inhibition: > 32500 nM
Compound 3 ended at the assay's limit; the forecaster's own chance of this, stated with the estimate: 60%; middle value at least 1.0-fold (0.03 log units) from the limit.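

Compound 1 and compound 3 both end at a limit of this assay, not at a number, so no step between them can be read: the limit of > 32500 nM in this assay, at which 2 of the 3 values shown sit.

On these data alone, whether 3,4-dichlorophenyl in place of 3-(trifluoromethyl)phenyl changes growth inhibition at all stays open.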